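Catechol vinyl sulfones: chain variation at the sulfonyl carbon

The source may hold more compounds than are shown below. What is called first, only, known or untested is meant among the compounds shown, and "the series" means these compounds.

Measured so far:
compound 1, `O=S(=O)(/C=C/c1ccc(O)c(O)c1)CC1CCCO1`, 10500 nM
compound 2, `CCCCCCCCCCCCS(=O)(=O)/C=C/c1ccc(O)c(O)c1`, 8500 nM
compound 3, `O=S(=O)(/C=C/c1ccc(O)c(O)c1)CC1CCCN1`, 13800 nM

All three share a catechol vinyl sulfone core and differ only in what sits on the saturated chain carbon bound to the sulfonyl sulfur. In a functional assay, read by fluorescence and spectrophotometry, with a stated time of 1 h (a higher number here means that more compound is needed for the effect, a lower number that less compound is needed), compound 1 gives 10500 nM, the second highest of the three numbers; compound 2 and compound 3 flank it, and all three values lie within the scatter of one another, so no order among them can be read.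

Compound 4, `CCCCCCCCS(=O)(=O)/C=C/c1ccc(O)c(O)c1`, has not been measured in this assay. Relative to compound 1 the change is heptyl in place of oxolan-2-yl on a saturated chain carbon bound to a sulfonyl sulfur. Among the measured compounds shown here, the one step measured at this same place, a 1.3-fold higher number from compound 1 to compound 3 (0.12 log units; within the scatter), did not leave the scatter. Compound 2, which carries a much longer chain at this place, gives 8500 nM, again within the scatter of compound 1. Nothing in the series shows the sulfonyl substituent moving this assay beyond the scatter, so no step beyond it is expected for compound 4 either.

Compound 4 is therefore expected to give about 9500 nM, within 4500 nM to 20000 nM, an estimated step of a 1.1-fold lower number from compound 1 to compound 4 (0.04 log units; within the scatter).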

Compound 4, half-maximal effective concentration: 6400 nM
Beside the measured number, compound 4's estimate is 1.5-fold (0.17 log units) above it, and the stated range covers the measured number.
By their numbers in this assay, from the lowest: compounds 4, 2, 1 and 3 (each within the scatter of the next, the first and the last beyond it).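

In this assay this position now holds a step beyond the scatter, though a modest one: heptyl in place of pyrrolidin-2-yl gives a 2.2-fold lower number from compound 3 to compound 4 (0.33 log units; beyond the scatter) on a saturated chain carbon bound to a sulfonyl sulfur. Heptyl in place of oxolan-2-yl gives a 1.6-fold lower number from compound 1 to compound 4 (0.22 log units; within the scatter) and stays within the scatter, so compound 1 cannot be separated from compound 3 or compound 4, and only the two ends of the series differ readably. Hydrogen in place of butyl, eight bonds along the chain from a sulfonyl sulfur, gives a 1.3-fold lower number from compound 2 to compound 4 (0.12 log units; within the scatter) and also stays within the scatter, so the heptyl and undecyl-length chains of this pair cannot be told apart here.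

On these data alone, whether the ring or its nitrogen sets compound 3 apart from compound 4 stays open, and a cyclopentyl group at this place would bear on that. Also open, as far as these compounds go, is whether a much shorter chain such as ethyl, or a chain ending in a carboxylic acid, would move the number beyond the scatter from compound 4.

Nothing shown alongside these values accounts for the one step beyond the scatter.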